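A few compounds are considered here, and "the series" means these few. Any claim that something is new, unique, unknown or untested is made for them only; others in the source may bear on it.

Compound 1, `ClCc1ccc(Cn2cnc3c(Cl)ncnc32)cc1`: 66100 nM
Compound 2, `ClCc1cccc(Cn2cnc3c(Cl)nc(Cl)nc32)c1`: 3630 nM

In a functional assay on HOP-92 cells (Homo sapiens) for cytotoxicity, read by sulforhodamine B assay, with a stated time of 48 h (on this read-out higher numbers stand for weaker inhibition of growth and lower numbers for stronger inhibition of growth), compound 1 gives 66100 nM, the higher of the two numbers shown. Compound 2 gives 3630 nM, a gap well beyond the usual scatter of this kind of measurement. The not yet measured compound 3, `Nc1nc(Cl)c2ncn(Cc3ccc(CCl)cc3)c2n1`, differs from compound 1 by one change: amino in place of hydrogen on an aromatic carbon. Going by the values given here, no measured pair shows this change, so the expectation rests on compound 1 alone: the estimated step of a 2.2-fold lower number from compound 1 to compound 3 (0.34 log units; beyond the scatter) points toward a somewhat lower number, close to the edge of the scatter. Compound 3 is expected to give 30000 nM, in the range 8000 nM to 120000 nM.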

Compound 3, concentration for total growth inhibition: > 100000 nM
Compound 3: no number, only a limit; the forecaster's own chance of this, stated with the estimate: 10%; middle value at least 3.3-fold (0.52 log units) away from the limit.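

In this assay, compound 3 gives > 100000 nM, which is a limit of the assay and not a number. Amino in place of hydrogen, on this aromatic carbon between two ring nitrogen atoms, brings no sign of stronger inhibition of growth: the step is an at least 1.5-fold higher number from compound 1 to compound 3 (0.17 log units; that floor lies within the scatter). Going by these compounds, the limit fixes only a floor, so the true size of this step stays unknown.

On these data alone, whether a methoxy group or a methylamino group on this same carbon would give a lower number remains open. So does whether any group here can improve on hydrogen at all.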